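The compounds below may be only part of what the source reports. "The series", "measured", "known", "first", "only" and "open" are said of these compounds alone.

In a functional assay on the whole organism for inhibition, with Rattus norvegicus as the target, read by cytopathic effect and paw edema, at a dose of 100 mg/kg by the oral route (a higher number here means more inhibition at the dose given (going by the name of the read-out), a lower number less inhibition), compound 1 `O=C(Nc1ccccn1)c1c(O)c2cccnc2n(-c2ccccc2)c1=O` gives 14.6%. For the measured compounds named here, compound 2 `COc1ccc(NC(=O)c2c(O)c3cccnc3n(-c3ccccc3)c2=O)cc1` gives -1.9% in this assay, the lower of the two numbers measured so far, the gap to compound 1 being beyond the scatter. Going by the values given here, the step of a number 16.5 percentage points lower from compound 1 to compound 2 (beyond the scatter) is the one measured change on the amide-type nitrogen. Compound 3 `O=C(Nc1cccnc1)c1c(O)c2cccnc2n(-c2ccccc2)c1=O` differs from compound 2 by pyridin-3-yl in place of 4-methoxyphenyl on an amide-type nitrogen. That measured step bears on this change, which again exchanges the 4-methoxyphenyl for a pyridinyl ring; a modest rise is therefore expected, with an estimated step of a number 11.9 percentage points higher from compound 2 to compound 3 (beyond the scatter). Compound 3 is estimated at 10%, between -2% and 24%.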

Compound 3, a percentage reported as inhibition, in the whole organism at one dose (the size of the read-out at that dose, not a potency): 30.8%
Compound 3: middle estimate off by 20.8 percentage points, on the low side; the measured number lies above the stated range.
By their numbers in this assay, from the lowest: compound 2; then compound 1; then compound 3.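

Pyridin-3-yl in place of pyridin-2-yl on the amide-type nitrogen gives a number 16.2 percentage points higher from compound 1 to compound 3 (beyond the scatter) and shows that the two pyridinyl groups are not interchangeable at this position. Pyridin-3-yl in place of 4-methoxyphenyl gives a number 32.7 percentage points higher from compound 2 to compound 3 (beyond the scatter) and is the largest step among these compounds. Compound 3 now stands highest of the three, with both its steps beyond the scatter.

Going by these compounds, whether pyridin-4-yl or a phenyl ring carrying a carboxylic acid would hold this level remains open. No measurement at hand accounts for these differences.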